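Adding a second methyl to the aryl ring of compound 2

This account rests on a few compounds, and the source may have more. Where it says the series, first, only, none or still open, it means among the compounds named here.

Compound 1, `Sc1nnc(COc2ccc(-c3ccccc3)cc2)n1-c1ccc(Cl)cc1`: 15.9%
Compound 2, `Cc1ccccc1-n1c(S)nnc1COc1ccc(-c2ccccc2)cc1`: 56.8%

Two compounds share a core and differ only in the ring attached to an aromatic nitrogen. In a functional assay on the whole organism (strain Wistar) for inhibition, with Rattus norvegicus as the target, read by paw edema, with a stated time of 3 h, at a dose of 10 mg/kg by the oral route (a higher number here means more inhibition at the dose given (going by the name of the read-out), a lower number less inhibition), compound 1 gives 15.9%. Compound 2 carries a 2-methylphenyl in place of the 4-chlorophenyl on that nitrogen, and in this assay compound 2 gives 56.8%. The step of a number 40.9 percentage points higher from compound 1 to compound 2 (beyond the scatter) is large and sets compound 2 at the highest of the two numbers measured, with compound 1 well below it.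

Compound 3, `Cc1ccc(-n2c(S)nnc2COc2ccc(-c3ccccc3)cc2)c(C)c1`, has not yet been measured. It differs from compound 2 by methyl in place of hydrogen on an aromatic carbon, sitting on a six-membered aromatic ring of carbon only, meta to a methyl group and para to a large group; cut one bond further out, the change reads 2-methylphenyl to 2,4-dimethylphenyl. Among the compounds with values here, the single measured step swaps one whole ring for another, so no measured step bears directly on adding a methyl to a ring that already carries one. With nothing to point either way, the expected step of a number 1.8 percentage points lower from compound 2 to compound 3 (within the scatter) is none beyond the scatter. Compound 3 is therefore estimated at 55%, within a range from 35% to 75%.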

Compound 3, a percentage reported as inhibition, in the whole organism at one dose (the size of the read-out at that dose, not a potency): 54.5%
Estimate against measurement, compound 3: 0.5 percentage points above, within the range that was stated.
By their numbers in this assay, from the lowest: compound 1; then compounds 3 and 2 (each within the scatter of the next).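

In this assay, putting a methyl on the aromatic carbon that is para to a large group and meta to the existing methyl gives a number 2.3 percentage points lower from compound 2 to compound 3 (within the scatter), so at this place on the ring the added methyl leaves the read-out within the scatter of compound 2. The change from 2-methylphenyl to 2,4-dimethylphenyl thus keeps the large gap to compound 1, with a number 38.6 percentage points higher from compound 1 to compound 3 (beyond the scatter), which shows that the 4-chlorophenyl compound's low number does not come with every ring bearing a group at that place. Nothing available here explains why the methyl changes so little or why compound 1 stays so far below the other two.

Since compound 1 differs from compound 3 in two groups on the same ring, these compounds cannot say whether the gap follows the loss of the chlorine or the presence of the 2-methyl, a question a 2-methyl-4-chlorophenyl ring would address. From the compounds shown here alone, it also remains open whether this place accepts only something as small as a methyl, or also a longer chain such as butyl, an amine or a carboxylic acid.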